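Trimming a Methoxy Group From the Side-Chain Aryl

The source may report more compounds than this note shows. Statements on the series, on what has been measured and on what is new or still open speak of the compounds shown alone.

Of the compounds shown here, three built on one shared core have been tested in an assay on isolated protein for inhibition of aldehyde dehydrogenase 1A1 (Homo sapiens); on this read-out higher numbers stand for weaker inhibition and lower numbers for stronger inhibition. Compound 1 `CC(Sc1nc2c(cnn2C)c(=O)n1-c1ccc(CCO)cc1)c1ccccc1` gives 360 nM. Compound 2 `CC(Sc1nc2c(cnn2C)c(=O)n1-c1ccccc1)c1cccnc1` gives 139 nM. Among the compounds with values here, compound 3 `COc1ccccc1C(C)Sc1nc2c(cnn2C)c(=O)n1-c1ccccc1` gives 445 nM, the highest of the three numbers; it lies within the scatter of compound 1 and beyond the scatter of compound 2, the one single-place step among the measured compounds being a 3.2-fold higher number from compound 2 to compound 3 (0.51 log units; beyond the scatter).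

Compound 4 `CC(Sc1nc2c(cnn2C)c(=O)n1-c1ccccc1)c1ccccc1` differs from compound 3 in one place: hydrogen in place of methoxy on an aromatic carbon.

Within the data shown here, no measured step removes a methoxy on its own. Among the measured compounds shown here, the only step that touches this part of the molecule, a 3.2-fold higher number from compound 2 to compound 3 (0.51 log units; beyond the scatter), exchanges the whole ring, so it cannot tell how much of that change belongs to the methoxy and how much to the ring itself. Compound 1 carries a plain phenyl on the same chain carbon but differs elsewhere, so its value is only a loose anchor. The expectation for compound 4 is therefore a step of a 2.0-fold lower number from compound 3 to compound 4 (0.31 log units; beyond the scatter), toward a somewhat lower number, held with wide uncertainty. Compound 4 is estimated at 220 nM, expected to fall between 80 nM and 600 nM.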

Compound 4, half-maximal inhibitory concentration: 130 nM
Compound 4: middle estimate off by 1.7-fold (0.23 log units), on the high side, and the stated range covers the measured number.
By their numbers in this assay, from the lowest: compounds 4 and 2 (each within the scatter of the next); then compounds 1 and 3 (each within the scatter of the next).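

In this assay, within the data shown here, the step of a 3.4-fold lower number from compound 3 to compound 4 (0.53 log units; beyond the scatter) is the first to remove the methoxy on its own, and it shows that swapping 2-methoxyphenyl for phenyl, with hydrogen on that aromatic carbon ortho to a large group, gives stronger inhibition. The ring itself now separates from the methoxy: the step of a 1.1-fold lower number from compound 2 to compound 4 (0.03 log units; within the scatter) lies within the scatter, so phenyl and pyridin-3-yl cannot be told apart here, and the earlier ring exchange, a 3.2-fold higher number from compound 2 to compound 3 (0.51 log units; beyond the scatter) in size, is matched closely by the removal of the methoxy alone. Compound 4 also gives a clean reading at a second place on the molecule, where hydrogen in place of 2-hydroxyethyl gives a 2.8-fold lower number from compound 1 to compound 4 (0.44 log units; beyond the scatter) and so also stronger inhibition.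

Nothing given here accounts for why the methoxy or the 2-hydroxyethyl weakens inhibition. The compounds shown also leave open whether the penalty belongs to methoxy alone or would also come with a methyl, a chlorine or a hydroxyl on the same aromatic carbon.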